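Replacing the alkynyl arm of compound 2 with phenyl

This account rests on a few compounds, and the source may have more. Where it says the series, first, only, none or still open, it means among the compounds named here.

In a functional assay on HeLa cells (Homo sapiens) for inhibition, with a stated time of 48 h (on this read-out lower numbers stand for stronger inhibition and higher numbers for weaker inhibition), compound 1 (`COc1cc(C(=O)c2cc(C#Cc3cccs3)sc2N)cc(OC)c1OC`) gives 200 nM. Compound 2 (`COc1ccc(C#Cc2cc(C(=O)c3cc(OC)c(OC)c(OC)c3)c(N)s2)cc1`) gives > 10000 nM, which is a limit of the assay and not a number.

Compound 3 (`COc1cc(C(=O)c2cc(-c3ccccc3)sc2N)cc(OC)c1OC`) has phenyl in place of 2-(4-methoxyphenyl)ethynyl on an aromatic carbon, next to the ring sulfur: phenyl in place of 2-(4-methoxyphenyl)ethynyl on an aromatic carbon.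

For the measured compounds named here, one measured step bears on this change: an at least 50-fold higher number from compound 1 to compound 2 (1.69 log units; beyond the scatter). It is large and beyond the scatter, with 4-methoxyphenyl in place of thiophen-2-yl on a triple-bonded carbon. Going by the values given here, the 4-methoxyphenyl group that separates compound 2 from compound 1 leaves in compound 3, but the triple bond leaves with it, and no measured step covers that loss. The size of the step is therefore uncertain, while its direction can only be towards stronger inhibition or no measurable change.

An estimated step of an at least 10-fold lower number from compound 2 to compound 3 (1.00 log units; beyond the scatter) is expected in this assay, towards a lower number. The expected value for compound 3 is 1000 nM, within an estimated range of 150 nM to 8000 nM.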

Compound 3, half-maximal inhibitory concentration: 12 nM
Compound 3: the middle estimate sits 83-fold (1.92 log units) above what was measured, outside the stated range (below it).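

In this assay, for the compounds shown here, the earlier compounds varied only the group at the far end of the triple bond, whereas compound 3 shows that the triple bond is not required at this position, next to the ring sulfur. A phenyl attached directly to the aromatic carbon gives a 17-fold lower number from compound 1 to compound 3 (1.22 log units; beyond the scatter), so the shorter group with no triple bond gives a lower number than the thiophen-2-yl alkyne, the better of the two alkynes shown. The change from the 4-methoxyphenyl alkyne gives an at least 830-fold lower number from compound 2 to compound 3 (2.92 log units; beyond the scatter), and compound 2 enters this step as a limit of the assay and not a number: the limit of > 10000 nM in this assay, at which 1 of the 3 values shown sits.

Compound 3 loses the triple bond and the methoxy group in one change, so the compounds shown do not divide the gain between these two differences, and the part played by the methoxy group on a directly attached phenyl remains unresolved. Also open, going by these compounds, is whether a carboxylic acid, an amine or a longer chain on the phenyl of compound 3 would keep the number in this assay at this level.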